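The source may report more compounds than this note shows. Statements on the series, on what has been measured and on what is new or still open speak of the compounds shown alone.

Compound 1 (`O=C(Cc1csc2nc(-c3ccc(Br)cc3)cn12)N/N=C/c1ccccc1`): 27500 nM
Compound 2 (`O=C(Cc1csc2nc(-c3ccc(Br)cc3)cn12)N/N=C/c1ccc(O)cc1`): 26300 nM
Compound 3 (`COc1cccc(OC)c1/C=N/NC(=O)Cc1csc2nc(-c3ccc(Br)cc3)cn12`): 26300 nM

All three values come from a functional assay (786-0 cells, Homo sapiens) for inhibition, read by sulforhodamine B assay, with a stated time of 48 h (on this read-out lower numbers stand for stronger inhibition of growth and higher numbers for weaker inhibition of growth), and sit close together. Compound 3 (26300 nM) stands level with compound 2 and within the scatter of compound 1. The unmeasured compound 4 (`O=C(Cc1csc2nc(-c3ccc(Br)cc3)cn12)N/N=C/c1ccc(Cl)cc1Cl`) carries 2,4-dichlorophenyl in place of 2,6-dimethoxyphenyl on a carbon with a double bond to nitrogen.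

Among the measured compounds shown here, three measured steps bear on this change because they concern the same aromatic group: a 1.0-fold lower number from compound 1 to compound 2 (0.02 log units; within the scatter), a 1.0-fold lower number from compound 1 to compound 3 (0.02 log units; within the scatter) and no change at the digits printed from compound 2 to compound 3 (within the scatter). Each lies within the scatter, so no step beyond the scatter is expected in this assay. For the measured compounds named here, none of the measured compounds carries chlorine, however, so this support is indirect and the range is kept wide.

The expected step is small and within the scatter (a 1.2-fold lower number from compound 3 to compound 4 (0.08 log units; within the scatter)). For compound 4 the estimated value is 22000 nM, with an expected range from 10000 nM to 45000 nM.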

Compound 4, concentration for 50% growth inhibition: 25700 nM
The estimate for compound 4 lay 1.2-fold (0.07 log units) below the measured number; the measured number falls inside the stated range.
By their numbers in this assay, from the lowest: compounds 4, 2, 3 and 1 (each within the scatter of the next).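

In this assay, 2,4-dichlorophenyl on the carbon with a double bond to nitrogen stays within the scatter of all three earlier groups: a 1.0-fold lower number from compound 3 to compound 4 (0.01 log units; within the scatter), a 1.0-fold lower number from compound 2 to compound 4 (0.01 log units; within the scatter) and a 1.1-fold lower number from compound 1 to compound 4 (0.03 log units; within the scatter). The earlier compounds had shown this level result only for phenyl, 4-hydroxyphenyl and 2,6-dimethoxyphenyl, and compound 4 extends it to a ring carrying chlorine and no hydrogen-bond acceptors. Nothing in the data explains why the number stays level across these groups.

Going by these compounds, it remains open whether any group at this place can move the number beyond the scatter, for instance a phenyl ring carrying an amine or a carboxylic acid, or a longer chain in place of the ring. The compounds shown also leave open how far changes to the shared core would shift the number.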